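This account rests on a few compounds, and the source may have more. Where it says the series, first, only, none or still open, it means among the compounds named here.

Compound 1, `CC(C)(C)c1ccc(-c2ccc(NCc3ccccc3O)cc2)cc1`: "not active" (no number reported)
Compound 2, `CCSc1ccc(-c2ccc(NCc3ccccc3O)cc2)cc1`: 1980 nM

Of the compounds shown here, two with a shared core have been tested in a functional assay on Jurkat cells (Homo sapiens) for activation, with a stated time of 24 h; a lower number here means that less compound is needed, a higher number that more compound is needed for the effect. Compound 1 `CC(C)(C)c1ccc(-c2ccc(NCc3ccccc3O)cc2)cc1` gave "not active" (no number reported), so no number stands beside it. Among the measured compounds shown here, compound 2 `CCSc1ccc(-c2ccc(NCc3ccccc3O)cc2)cc1` gave 1980 nM; in this assay this is the only number reported, and compound 1 adds no single number, so compound 2 is the sole reference point here. Compound 3 `CC(C)Oc1ccc(-c2ccc(NCc3ccccc3O)cc2)cc1` differs from compound 2 in one place: isopropoxy in place of ethylsulfanyl on an aromatic carbon. For the measured compounds named here, no step between two measured compounds of this kind has been recorded, so the size of this change cannot be read from the data. The step of a 1.3-fold higher number from compound 2 to compound 3 (0.10 log units; within the scatter) is expected to be small, leaning toward a somewhat higher number rather than a lower one. Compound 3 is therefore estimated at 2500 nM, in the range from 800 nM to 8000 nM.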

Compound 3, half-maximal effective concentration: 5940 nM
Beside the measured number, compound 3's estimate is 2.4-fold (0.38 log units) below it, within the range that was stated.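

In this assay, swapping ethylsulfanyl for isopropoxy on this aromatic carbon, para to a large group, gives a 3.0-fold higher number from compound 2 to compound 3 (0.48 log units; beyond the scatter). Among the compounds shown here, this is the first change at this position whose size can be read, since compound 1 has no number, and it shows that the choice of group here shifts the result measurably, even though both groups allow a numerical result. No measurement shown here offers an explanation for the step.

The step changes both the linking atom and the shape of the chain, so ethoxy or isopropylsulfanyl would be needed to separate those two changes. How an amine or a carboxylic acid at this position would fare also remains an open question.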